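The compounds below may be only part of what the source reports. "The series", "measured", "known", "first", "only" and "open" are said of these compounds alone.

In an assay on HEK293 cells for positive allosteric modulation of metabotropic glutamate receptor 5 (Homo sapiens), read by FLIPR (on this read-out higher numbers stand for an effect only at larger amounts of compound and lower numbers for an effect already at smaller amounts), compound 2 `Cc1cccc(-c2noc(C3CN(C(=O)C4CCC(C(F)(F)F)CC4)C3)n2)c1` gives 1000 nM. That is the only number among the three results shown; the other two are limits of the assay, namely (the limit of > 10000 nM in this assay, at which 2 of the 3 values shown sit). Compound 1 `Cc1cccc(-c2noc(C3CN(S(=O)(=O)c4ccc(Cl)cc4)C3)n2)c1` gives > 10000 nM, a limit. Compound 3 `Cc1ccc(S(=O)(=O)N2CC(c3nc(-c4cccc(Cl)c4)no3)C2)cc1` gives > 10000 nM, also a limit. Compound 4 `O=C(C1CCC(C(F)(F)F)CC1)N1CC(c2nc(-c3cccc(Cl)c3)no2)C1` has not yet been measured. It differs from compound 2 by chloro in place of methyl on an aromatic carbon, which, cut one bond further out, reads 3-methylphenyl to 3-chlorophenyl. Among the measured compounds shown here, no measured pair shows this change with numbers on both sides, so a step of no more than the usual scatter is expected, in no particular direction. The step of no change at the digits printed from compound 2 to compound 4 (within the scatter) is expected. Compound 4 is estimated at 1000 nM, with a range from 400 nM to 3000 nM.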

Compound 4, half-maximal effective concentration: 1000 nM
The estimate for compound 4 equals the measured number at the digits printed; the measured number falls inside the stated range.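

In this assay, compounds 2 and 4 form the first pair shown that differs in one place and has numbers on both sides. Putting chloro in place of methyl on the aromatic carbon gives no change at the digits printed from compound 2 to compound 4 (within the scatter), so at this position of the amide compounds, 3-chlorophenyl and 3-methylphenyl cannot be told apart. Nothing measured here bears on the reason for this.

The compounds shown leave open what a methoxy group, a nitrile or an amine would do at this place. With only methyl and chloro compared, they also give no trend across groups.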